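The source may hold more compounds than are shown below. What is called first, only, known or untested is meant among the compounds shown, and "the series" means these compounds.

Compound 1 `CC(C)NC(=O)c1ccc(NCc2cncn2Cc2ccc(C#N)cc2)cc1-c1ccccc1`: in a functional assay on NIH3T3 cells (Mus musculus) (on this read-out higher numbers stand for an effect only at larger amounts of compound and lower numbers for an effect already at smaller amounts), compound 1 gives > 10 uM, which is a limit of the assay.
Compound 2 `COC(=O)[C@H](CCSC)NC(=O)c1ccc(NCc2cncn2Cc2cccc(C#N)c2)cc1-c1ccccc1`: in this assay compound 2 gives > 10 uM, again a limit.
Compound 3 `CSCC[C@H](NC(=O)c1ccc(NCc2cncn2Cc2cccc(C)c2)cc1-c1ccccc1)C(=O)O`: in this assay compound 3 gives > 10 uM, also a limit.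

For the measured compounds named here, compound 3 therefore stands at the limit of > 10 uM in this assay, at which 3 of the 3 values shown sit; no true number is known for it or for the two other compounds, so no step between measured compounds can be read. Compound 4 `CSCC[C@H](NC(=O)c1ccc(NCc2cncn2Cc2ccc([N+](=O)[O-])cc2)cc1-c1ccccc1)C(=O)O` differs from compound 3 by 4-nitrophenyl in place of 3-methylphenyl on a saturated chain carbon bound to an aromatic nitrogen. With every measured value sitting at the limit, the expected step from compound 3 to compound 4 is a step that the limit leaves unreadable from compound 3 to compound 4, that is, nothing beyond the scatter. Compound 4 is therefore expected to give about 15 uM in this assay, within a range from 4 uM to 60 uM, most likely again reported only as a limit.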

Compound 4, concentration for half-maximal effect: > 10 uM
Compound 4 was reported as a limit; the forecaster's own chance of this, stated with the estimate: 75%; the middle value lies beyond the limit too.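

For the compounds shown here, no step from compound 3 to compound 4 can be read, because both sit at the same limit: the limit of > 10 uM in this assay, at which 4 of the 4 values shown sit.
In this assay the compounds shown leave open their true values, and whether 3-methylbenzyl or 4-nitrobenzyl makes any difference.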